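Swapping fluoro for chloro on the anilide ring

The source may hold more compounds than are shown below. What is called first, only, known or untested is meant among the compounds shown, and "the series" means these compounds.

Measured compounds:
compound 1 `CC1=C(C(=O)Nc2ccc(F)c(Cl)c2)C(c2ccccc2Cl)NC(=S)N1` gives 16600 nM
compound 2 `CC1=C(C(=O)Nc2ccc(F)c(Cl)c2)C(c2cccc(Oc3ccccc3)c2)NC(=S)N1` gives 15500 nM
compound 3 `CC1=C(C(=O)Nc2ccc(Cl)c(Cl)c2)C(c2cccc(Oc3ccccc3)c2)NC(=S)N1` gives 15500 nM

Of the compounds shown here, three have been tested in a functional assay on NCI/ADR-RES cells (Homo sapiens) for cytotoxicity, read by sulforhodamine B assay, with a stated time of 48 h; a higher number here means a weaker inhibitor of growth, a lower number a stronger inhibitor of growth. Compound 1 and compound 2 share most of their structure but differ in more than one place, and the difference between the two cores is not broken down here; their values in this assay sit within the usual scatter of each other, so no order between them can be read. From compound 2 to compound 3 the change is chloro in place of fluoro on an aromatic carbon, and the step in this assay is no change at the digits printed from compound 2 to compound 3 (within the scatter).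

Compound 4 `CC1=C(C(=O)Nc2ccc(Cl)c(Cl)c2)C(c2ccccc2Cl)NC(=S)N1` has not yet been measured. It arises from compound 1 by chloro in place of fluoro on an aromatic carbon, the same change that turned compound 2 into compound 3. Because that earlier step read no change at the digits printed from compound 2 to compound 3 (within the scatter), the step from compound 1 to compound 4 is expected to be small as well, no change at the digits printed from compound 1 to compound 4 (within the scatter), resting on a single precedent. Compound 4 is therefore expected to give about 16600 nM in this assay, with a plausible range from 8000 nM to 34000 nM.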

Compound 4, concentration for 50% growth inhibition: 15800 nM
Compound 4: middle estimate off by 1.1-fold (0.02 log units), on the high side; measured number inside the range.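

In this assay the change from 3-chloro-4-fluorophenyl to 3,4-dichlorophenyl on the core of compound 1 leaves the reading essentially where it was (a 1.1-fold lower number from compound 1 to compound 4 (0.02 log units; within the scatter)). Set beside the earlier step, the swap reads alike on both cores: the same change on two cores in this assay, no change at the digits printed (within the scatter) from compound 2 to compound 3 and a 1.1-fold lower number (0.02 log units; within the scatter) from compound 1 to compound 4, 1.1-fold (0.02 log units) apart, within the scatter of two such steps. So on these two cores, chloro in place of fluoro at this spot carries over as a step too small to read, but two such steps do not show that it would stay this small on a third core, and they say nothing about why it is so small.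

The compounds shown leave open whether anything other than a halogen at this spot, such as a methoxy group, an amine or a carboxylic acid, would move the reading beyond the scatter. They also leave open whether a step large enough to read would carry from one core to the other as faithfully as this one did.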